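The source may report more compounds than this note shows. Statements on the series, on what has been measured and on what is new or still open speak of the compounds shown alone.

Measured in a functional assay on SR cells (Homo sapiens) for inhibition, read by sulforhodamine B assay, with a stated time of 48 h; on this read-out higher numbers stand for weaker inhibition of growth and lower numbers for stronger inhibition of growth:
compound 1 `COc1cc(-c2nn(-c3cccc(NC(=O)c4cccc(C(F)(F)F)c4)c3)cc2-c2ccncc2)ccc1Cl`: 838 nM
compound 2 `COc1cc(-c2nn(-c3cccc(NC(=O)Nc4cccc(C(F)(F)F)c4)c3)cc2-c2ccncc2)ccc1Cl`: 886 nM
compound 3 `COc1cc(-c2nn(-c3cccc(NC(=O)c4ccc(Cl)c(C(F)(F)F)c4)c3)cc2-c2ccncc2)ccc1Cl`: 848 nM

Compound 3 lies within the scatter of both other compounds, so the three values cannot be ordered. Compound 4 `COc1cc(-c2nn(-c3cccc(NC(=O)c4ccccc4)c3)cc2-c2ccncc2)ccc1Cl` differs from compound 3 by phenyl in place of 4-chloro-3-(trifluoromethyl)phenyl on a carbonyl carbon.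

Going by the values given here, one measured step bears directly on part of this change. Chloro in place of hydrogen gave a 1.0-fold higher number from compound 1 to compound 3 (0.01 log units; within the scatter), so losing the chloro is expected to matter little. The urea comparison, a 1.1-fold higher number from compound 1 to compound 2 (0.02 log units; within the scatter), and a 1.0-fold lower number from compound 2 to compound 3 (0.02 log units; within the scatter) were also within the scatter, but neither touches the trifluoromethyl. Among the compounds with values here, no compound without trifluoromethyl has been measured, so that part of the change is untested and the range must stay wide. Expected is a 1.3-fold higher number from compound 3 to compound 4 (0.11 log units; within the scatter), a modest step towards weaker inhibition of growth, and it may not exceed the scatter. For compound 4 the estimated value in this assay is 1100 nM, with an expected range of 450 nM to 2800 nM.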

Compound 4, concentration for 50% growth inhibition: 250 nM
Beside the measured number, compound 4's estimate is 4.4-fold (0.64 log units) above it, outside the stated range (below it).
By their numbers in this assay, from the lowest: compound 4; then compounds 1, 3 and 2 (each within the scatter of the next).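

In this assay, hydrogen in place of trifluoromethyl on an aromatic carbon produces a change beyond the scatter, with a 3.4-fold lower number from compound 1 to compound 4 (0.53 log units; beyond the scatter). The same unsubstituted phenyl on the carbonyl carbon also separates from the other two compounds, with a 3.4-fold lower number from compound 3 to compound 4 (0.53 log units; beyond the scatter) and a 3.5-fold lower number from compound 2 to compound 4 (0.55 log units; beyond the scatter), so this group responds to substitution in a way that the chloro and urea steps, all taken with trifluoromethyl present, did not show. No measurement here explains the shift.

Open, as far as these compounds go, is whether trifluoromethyl is specifically unfavourable or any group at that aromatic carbon gives the same result, which a methyl, a methoxy or a dimethylamino group there would test. Also open, from the compounds shown here alone, is whether chloro alone on the phenyl, or a urea carrying unsubstituted phenyl, would keep the lower number.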